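This account rests on a few compounds, and the source may have more. Where it says the series, first, only, none or still open, it means among the compounds named here.

The study begins from compound 1, `C=C[C@@](C)(/C=C/c1ccc(OCc2ccccc2)cc1)CCC=C(C)C`, which in a functional assay on Raji cells (Homo sapiens) for cytotoxicity, with a stated time of 72 h (a higher number here means that more compound is needed for the effect, a lower number that less compound is needed), gives only a limit of the assay rather than a number: compound 1 reads > 26000 nM. Compound 2, `C=C[C@@](C)(/C=C/c1ccc(O)cc1)CC/C=C/C(=O)OCC`, is likewise recorded in this assay as a limit, with compound 2 giving > 26000 nM. For the measured compounds named here, both values measured so far thus rest at the same boundary (the limit of > 26000 nM in this assay, at which 2 of the 2 values shown sit), and no step between two measured compounds can be read from them. Compound 3, `C=C[C@@](C)(/C=C/c1ccc(-c2cccc(F)c2)cc1)CCC=C(C)C`, has not yet been tested in this assay. Compared with compound 1 it carries 3-fluorophenyl in place of benzyloxy on an aromatic carbon. With both known values sitting at the limit, there is no measured direction to lean on, and the step is expected to be an at least 1.3-fold lower number from compound 1 to compound 3 (0.11 log units; that floor lies within the scatter), that is, no change that can be told apart from the scatter, with a real chance that the reading again stops at the boundary. Compound 3 is therefore estimated to come out at 20000 nM in this assay, within a range from 5000 nM to 60000 nM.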

Compound 3, half-maximal effective concentration: > 26000 nM
Compound 3: only a limit was reported; the forecaster's own chance of this, stated with the estimate: 65%; middle value at least 1.3-fold (0.11 log units) from the limit.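

Compound 3, like compound 1, is recorded in this assay only as a limit of the assay, so no step can be read between compound 1 and compound 3 for the swap of benzyloxy to 3-fluorophenyl. All the readings shown share one boundary: the limit of > 26000 nM in this assay, at which 3 of the 3 values shown sit.

The compounds shown leave open what concentration, if any, produces the effect in these cells.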